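Moving the hydroxy group on the amide-bearing ring

The source may report more compounds than this note shows. Statements on the series, on what has been measured and on what is new or still open speak of the compounds shown alone.

Compound 3 `O=C(Nc1ccc(O)cc1)c1cc2cc(Cl)cc(Br)c2oc1=O` carries a 4-hydroxyphenyl on the amide-type nitrogen of the shared core. In an assay on isolated protein for inhibition of coagulation factor XII (Homo sapiens), read by HPLC, with stated times of 10 min and 30 min, tested at 50 uM (a lower number here means less inhibition, a higher number more inhibition at the concentration tested (going by the name of the read-out)), compound 3 gives 90%, level with compound 1 `O=C(Nc1ccccc1)c1cc2cc(Cl)cc(Br)c2oc1=O`, which gives 90%; together these are the lowest of three numbers. no change at the digits printed from compound 1 to compound 3 (within the scatter). Compound 2 `O=C(Nc1cc(Cl)ccc1O)c1cc2cc(Cl)cc(Br)c2oc1=O` gives 99%; a number 9 percentage points lower from compound 2 to compound 3 (within the scatter), and a number 9 percentage points higher from compound 1 to compound 2 (within the scatter). Compound 4 `O=C(Nc1cccc(O)c1)c1cc2cc(Cl)cc(Br)c2oc1=O` differs from compound 3 only in this way: 3-hydroxyphenyl in place of 4-hydroxyphenyl on an amide-type nitrogen. All three measured steps stay within the scatter, and every change so far to the ring on the amide-type nitrogen has left this assay near its top, so a step within the scatter is expected, a number 2 percentage points lower from compound 3 to compound 4 (within the scatter). Compound 4 is therefore estimated at 88%, with a range from 75% to 99%.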

Compound 4, a percentage reported as inhibition, at one concentration (the size of the read-out at that concentration, not a potency) in the coagulation factor XII assay: 90%
Estimate against measurement, compound 4: 2 percentage points below; measured number inside the range.
By their numbers in the coagulation factor XII assay, from the lowest: compounds 1, 3, 4 and 2 (each within the scatter of the next).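

In the coagulation factor XII assay compound 4 gives 90% and the shift of the hydroxy group gives no change at the digits printed from compound 3 to compound 4 (within the scatter) and so makes no difference that this assay can read, while the 3-hydroxyphenyl set against the plain phenyl gives no change at the digits printed from compound 1 to compound 4 (within the scatter) and set against the 5-chloro-2-hydroxyphenyl gives a number 9 percentage points lower from compound 2 to compound 4 (within the scatter). In a physicochemical assay for solubility, at pH 6.5 (a lower number here means a less soluble compound, a higher number a more soluble compound), compound 3 gives 1.5 ug/mL and compound 4 gives 1.4 ug/mL and the same swap gives a 1.1-fold lower number from compound 3 to compound 4 (0.03 log units; within the scatter) and therefore stays equally flat in this second read-out. Nothing offered here accounts for these results. What the compounds shown leave open is whether an amine or a carboxylic acid in place of the hydroxy on this ring would move either read-out.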